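Replacing phenyl with pyridin-4-yl on compound 1

The source may hold more compounds than are shown below. What is called first, only, known or untested is meant among the compounds shown, and "the series" means these compounds.

Of the compounds shown here, three on the shared core have been read so far in a functional assay (aorta) with Rattus norvegicus as the target (a lower number here means a stronger inhibitor, a higher number a weaker inhibitor), and no pair among them differs in one place only. Compound 1 (`CC1(C)Oc2ccc(C#N)cc2[C@@H](NC(=O)Nc2ccccc2)[C@@H]1O`) gives 800 nM as its half-maximal inhibitory concentration, the lower of the two actual numbers. Compound 3 (`CCC(C)(C)/N=C(\NC#N)N[C@@H]1c2cc(C#N)ccc2OC(C)(C)[C@H]1O`) gives 29800 nM as its reading, a gap to compound 1 that lies beyond the scatter. Compound 2 (`CC1(C)Oc2ccc(C#N)cc2[C@@H](/N=C(\NC#N)Oc2ccccc2)[C@@H]1O`) reads > 100000 nM in this assay and this is a limit of the assay, not a number.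

The next compound is compound 4 (`CC1(C)Oc2ccc(C#N)cc2[C@@H](NC(=O)Nc2ccncc2)[C@@H]1O`), with pyridin-4-yl in place of phenyl on an amide-type nitrogen. Within the data shown here, no measured step shows this exchange, so the expectation is broad and starts from compound 1 at 800 nM as the reference point. A move to a higher number in this assay is expected, meaning a weaker inhibitor, and the estimated move, a 3.8-fold higher number from compound 1 to compound 4 (0.57 log units; beyond the scatter), is of moderate size beyond the scatter. For compound 4 the estimate is 3000 nM with an expected range from 500 nM to 20000 nM in this read-out.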

Compound 4, half-maximal inhibitory concentration: 8500 nM
Compound 4: middle estimate off by 2.8-fold (0.45 log units), on the low side; low and high end bracket the measured number.
By their numbers in this assay, from the lowest: compound 1; then compound 4; then compound 3. At a limit, above all of these: compound 2.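

In this assay, among these compounds, the exchange of pyridin-4-yl for phenyl on an amide-type nitrogen gives an 11-fold higher number from compound 1 to compound 4 (1.03 log units; beyond the scatter) and is the first one-place step read. This position is therefore sensitive to a change of one ring carbon for one ring nitrogen, even though the heavy-atom count stays the same and neither group carries a net charge. Within this single pair, phenyl gives the stronger inhibitor and the added hydrogen-bond acceptor on pyridin-4-yl goes with the weaker one, but one pair sets no trend, and no measured property shown here accounts for the step.

Open, from the compounds shown here alone, is whether the loss follows from the presence of a ring nitrogen as such or from its place in the ring, which pyridin-3-yl and pyridin-2-yl on the same nitrogen would test. Also open, going by these compounds, is how far this place tolerates change of the ring itself, for example a cyclohexyl group or a 4-methoxyphenyl group in place of phenyl on the shared core.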